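The compounds below may be only part of what the source reports. "The series", "measured", "known", "first", "only" and "open" are said of these compounds alone.

Measured compounds and their values:
- compound 1, `O=C(NN=C(c1ccccn1)c1ccccn1)c1cccc(Br)c1`: 240 nM in an ADME assay on cells (Homo sapiens) for antiproliferative activity, read by MTT assay; a lower number here means a stronger inhibitor, a higher number a weaker inhibitor
- compound 2, `O=C(NN=C(c1ccccn1)c1ccccn1)c1ccc([N+](=O)[O-])cc1`: 260 nM in this assay

Among the two numbers in this assay, compound 2 holds the highest, and its nearest neighbour is compound 1, whose value lies within the scatter of it, so the two show no real separation. Compound 3, `Nc1ccc(C(=O)NN=C(c2ccccn2)c2ccccn2)cc1`, has not yet been measured in this assay. It differs from compound 2 by amino in place of nitro on an aromatic carbon. Among the compounds with values here, no step between measured compounds is available for this change, so the direction must be judged without a precedent. Given that compound 1 and compound 2 sit close together in this assay despite carrying different substituents on the shared core, the step from compound 2 to compound 3 is expected to be small, and probably not beyond the scatter in either direction. Compound 3 is therefore estimated at 300 nM, with a range from 120 nM to 800 nM, which corresponds to an expected step of a 1.2-fold higher number from compound 2 to compound 3 (0.06 log units; within the scatter).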

Compound 3, half-maximal inhibitory concentration: 7640 nM
The estimate for compound 3 lay 25-fold (1.41 log units) below the measured number; the whole stated range lies below it.
By their numbers in this assay, from the lowest: compounds 1 and 2 (each within the scatter of the next); then compound 3.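

Compound 1 and compound 2 carry different substituents, yet their values in this assay lie within the scatter of each other, which gave no sign that the substituent on this ring mattered. Amino in place of nitro on an aromatic carbon, para to a large group, now produces a 29-fold higher number from compound 2 to compound 3 (1.47 log units; beyond the scatter) and shows that this position is sensitive to the change; the replacement of 3-bromophenyl by 4-aminophenyl likewise gives a 32-fold higher number from compound 1 to compound 3 (1.50 log units; beyond the scatter) and sets compound 3 apart from both earlier compounds. No measured information here accounts for this step.

Going by these compounds, it remains open whether the step belongs to the amino group specifically or would also follow with a methoxy, hydroxyl or dimethylamino group on the same carbon. The compounds shown also leave open how an amino group would behave at the ring position that carries bromine in compound 1.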